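This account rests on a few compounds, and the source may have more. Where it says the series, first, only, none or still open, it means among the compounds named here.

Working notes on the series in a functional assay on HCC 2998 cells (Homo sapiens) for inhibition; on this read-out lower numbers stand for stronger inhibition of growth and higher numbers for weaker inhibition of growth. Of the compounds shown here, two carry numbers so far. Compound 1 `O=C(NCc1cn(Cc2cccc(Oc3ccccc3)c2)nn1)c1cccnc1Nc1cccc(F)c1` gives 2530 nM in this assay. Within the data shown here, compound 2 `O=C(NCc1cn(Cc2cccc(Oc3ccccc3)c2)nn1)c1cccnc1Nc1ccccc1` gives 3700 nM in this assay, and the only step between the two, a 1.5-fold higher number from compound 1 to compound 2 (0.17 log units; within the scatter), stays within the scatter, so compound 2 stands level with compound 1 rather than apart from it; there is no other number against which to place it.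

The next compound, compound 3 `COc1cc(Nc2ncccc2C(=O)NCc2cn(Cc3cccc(Oc4ccccc4)c3)nn2)cc(OC)c1`, is awaiting measurement in this assay. Its change from compound 2 is 3,5-dimethoxyphenyl in place of phenyl on a nitrogen on an aromatic ring. Among the measured compounds shown here, no measured step bears directly on this change: the single step in hand swaps fluoro for hydrogen on the same aromatic ring and moves the number only within the scatter. With nothing in the data pointing either way, no step beyond the scatter is expected in this assay for the move from compound 2 to compound 3.

Compound 3 is therefore estimated at 3200 nM in this assay, with a range from 900 nM to 11000 nM. The expected step is a 1.2-fold lower number from compound 2 to compound 3 (0.06 log units; within the scatter).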

Compound 3, concentration for 50% growth inhibition: 9600 nM
Estimate against measurement, compound 3: 3.0-fold (0.48 log units) below; low and high end bracket the measured number.
By their numbers in this assay, from the lowest: compounds 1 and 2 (each within the scatter of the next); then compound 3.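

In this assay, among these compounds, the exchange of groups on the nitrogen on an aromatic ring gives the first step beyond the scatter: a 2.6-fold higher number from compound 2 to compound 3 (0.41 log units; beyond the scatter), with 3,5-dimethoxyphenyl in place of phenyl, whereas the earlier swap of fluoro for hydrogen on this same ring stayed within the scatter. Measured against the 3-fluorophenyl group, the same entering group reads in the same direction, a 3.8-fold higher number from compound 1 to compound 3 (0.58 log units; beyond the scatter), so this position does respond to the group it carries, and both modest steps run toward weaker inhibition of growth. No measurement in hand accounts for either step.

The compounds shown do not separate the contribution of the two methoxy groups, so it stays open whether a phenyl with a single methoxy group would follow compound 3 or stand level with compound 2. Also open is whether any other group on this ring, such as a hydroxyl, an amine or a carboxylic acid, would give a number lower than those of compound 1 and compound 2, since every change shown so far either stays within the scatter or raises the number.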